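Ring substitution on the shared core and deacetylase inhibition

This account rests on a few compounds, and the source may have more. Where it says the series, first, only, none or still open, it means among the compounds named here.

Compound 1 `O=C(NO)c1ccc(NCc2nc(-c3ccccc3)nn2-c2ccccc2)cc1` stands highest of the two numbers in an assay on Sf9 cells for inhibition of protein deacetylase HDAC6 (Homo sapiens), read by fluorescence, with a stated time of 40 min, tested at 100 nM (a higher number here means more inhibition at the concentration tested (going by the name of the read-out), a lower number less inhibition), where compound 1 gives 72.6%. Compound 2 `O=C(NO)c1ccc(NCc2nc(-c3ccc(C(F)(F)F)cc3)nn2-c2ccccc2)cc1` gives 41.6%; the step of a number 31 percentage points lower from compound 1 to compound 2 (beyond the scatter) is large. Compound 3 `Cc1ccc(-n2nc(-c3ccccc3)nc2CNc2ccc(C(=O)NO)cc2)cc1C` differs from compound 1 by 3,4-dimethylphenyl in place of phenyl on an aromatic nitrogen. Going by the values given here, the only measured step concerns the phenyl on the ring carbon, not the group on the ring nitrogen, so it is at best a loose guide: a modest change in either direction, or none beyond the scatter, is plausible. For compound 3 the expected value is 65%, with a range of 42% to 85%, an estimated step of a number 7.6 percentage points lower from compound 1 to compound 3 (within the scatter).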

Compound 3, a percentage reported as inhibition, at one concentration (the size of the read-out at that concentration, not a potency): 53%
Compound 3: middle estimate off by 12 percentage points, on the high side; the measured number falls inside the stated range.
By their numbers in this assay, from the lowest: compound 2; then compound 3; then compound 1.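

In this assay, going by these compounds alone, the group on the aromatic nitrogen also moves the number: the step of a number 19.6 percentage points lower from compound 1 to compound 3 (beyond the scatter) is the first read at this position, the earlier step having concerned only the phenyl on the ring carbon. With 3,4-dimethylphenyl in place of phenyl, compound 1 still stands highest of the three numbers. No measurement at hand accounts for this drop.

Open, going by these compounds, is whether a single methyl would give the same step. Also open, on these data alone, is whether a methoxy group or an amine on this phenyl would move the number the same way.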